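A few compounds are considered here, and "the series" means these few. Any claim that something is new, unique, unknown or untested is made for them only; others in the source may bear on it.

Measured compounds in an ADME assay on Huh-7 cells (Homo sapiens) for cytotoxicity; on this read-out higher numbers stand for weaker inhibition and lower numbers for stronger inhibition:
- compound 1 `CN(c1cc2ncc(=O)[nH]c2cc1NC(=S)Nc1ccc(F)cc1)C1CCCCC1` gives 64300 nM
- compound 2 `CN(c1cc2ncc(=O)[nH]c2cc1NC(=S)Nc1cccc(C(F)(F)F)c1)C1CCCCC1` gives 78400 nM
- compound 3 `CN(c1cc2ncc(=O)[nH]c2cc1NC(=S)Nc1cccc2ccccc12)C1CCCCC1` gives 43600 nM

Compound 1 stands second highest of the three numbers. Its nearest neighbour is shown by a 1.2-fold higher number from compound 1 to compound 2 (0.09 log units; within the scatter) and its furthest by a 1.5-fold lower number from compound 1 to compound 3 (0.17 log units; within the scatter); both steps lie within the scatter, so the three compounds cannot be told apart on this read-out.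

Compound 4 `CN(c1cc2ncc(=O)[nH]c2cc1Nc1nc(-c2cccs2)cs1)C1CCCCC1` arises from compound 1 by the change (a group of 10 heavy atoms (7 carbon, 1 nitrogen, 2 sulfur; one five-membered aromatic ring with 1 hetero atom, one five-membered aromatic ring with 2 hetero atoms) in place of a group of 10 heavy atoms (7 carbon, 1 nitrogen, 1 fluorine, 1 sulfur; one six-membered aromatic ring of carbon only), on a nitrogen on an aromatic ring). Within the data shown here, none of the measured steps makes this exact exchange. What they do show is that swapping one aromatic group for another on the amide-type nitrogen, as in a 1.8-fold lower number from compound 2 to compound 3 (0.25 log units; within the scatter), left the number within the scatter each time. On that basis no step beyond the scatter is expected here either, although the entering group is built from two five-membered aromatic rings with hetero atoms rather than a six-membered aromatic ring of carbon only, which makes this a larger departure than the three measured changes.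

Compound 4 is therefore estimated at 55000 nM, with a range of 22000 nM to 130000 nM. The expected step from compound 1 is a 1.2-fold lower number from compound 1 to compound 4 (0.07 log units; within the scatter).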

Compound 4, half-maximal inhibitory concentration: 71300 nM
Compound 4: the middle estimate sits 1.3-fold (0.11 log units) below what was measured, and the stated range covers the measured number.
By their numbers in this assay, from the lowest: compounds 3, 1, 4 and 2 (each within the scatter of the next).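

In this assay, putting 4-(thiophen-2-yl)-1,3-thiazol-2-yl on this nitrogen gives a 1.1-fold higher number from compound 1 to compound 4 (0.04 log units; within the scatter). The earlier steps shown here only exchanged one six-membered aromatic group for another on the amide-type nitrogen, whereas this change also removes the double bond outside aromatic rings and the hydrogen-bond donor of the leaving group, and the number still does not move beyond the scatter. Nothing available here bears on what lies behind this result.

As far as these compounds go, all four compounds carry aromatic rings in the group at this place, so it remains open whether a group ending in a carboxylic acid or an amine would move the number beyond the scatter. They also share the rest of the core of compound 1, which leaves the effect of changes there open.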